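From isopropyl to a 4-(dipropylamino)butyl side chain

The compounds below may be only part of what the source reports. "The series", "measured", "known", "first", "only" and "open" are said of these compounds alone.

In a functional assay on LNCaP cells (Homo sapiens) for antiproliferative activity, read by WST assay, with a stated time of 3 days (a higher number here means a weaker inhibitor, a lower number a stronger inhibitor), compound 1 (`CCCOc1c(-c2cc(OC)c(OC)c(OC)c2)oc2ccccc2c1=O`) gives 5700 nM, compound 2 (`COc1cc(-c2oc3ccccc3c(=O)c2OC(C)C)cc(OC)c1OC`) gives 8800 nM and compound 3 (`CCCC(C)Oc1c(-c2cc(OC)c(OC)c(OC)c2)oc2ccccc2c1=O`) gives 15100 nM. Compound 2 lies within the scatter of both others. Compound 4 (`CCCN(CCC)CCCCOc1c(-c2cc(OC)c(OC)c(OC)c2)oc2ccccc2c1=O`) differs from it as follows: 4-(dipropylamino)butyl in place of isopropyl on an oxygen on an aromatic ring. Only simple alkyl swaps on this oxygen have been measured. The steps of a 1.5-fold higher number from compound 1 to compound 2 (0.19 log units; within the scatter) and a 1.7-fold higher number from compound 2 to compound 3 (0.23 log units; within the scatter) stay within the scatter, while a 2.6-fold higher number from compound 1 to compound 3 (0.42 log units; beyond the scatter) is modest. None of these groups holds a nitrogen, so they set no firm direction in this assay, and only a tentative, modest fall is expected. The expected step is a 2.2-fold lower number from compound 2 to compound 4 (0.34 log units; beyond the scatter). Compound 4 is estimated at 4000 nM, with a range from 800 nM to 15000 nM.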

Compound 4, half-maximal inhibitory concentration: 16800 nM
Estimate against measurement, compound 4: 4.2-fold (0.62 log units) below; the measured number lies above the stated range.
By their numbers in this assay, from the lowest: compounds 1, 2, 3 and 4 (each within the scatter of the next, the first and the last beyond it).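

In this assay, within the data shown here, the 4-(dipropylamino)butyl chain, the first group on this oxygen to hold a nitrogen, brings no clear gain over the simple alkyl groups: the steps are a 1.9-fold higher number from compound 2 to compound 4 (0.28 log units; within the scatter) and a 1.1-fold higher number from compound 3 to compound 4 (0.05 log units; within the scatter). Only the comparison with the propyl group leaves the scatter, with a 2.9-fold higher number from compound 1 to compound 4 (0.47 log units; beyond the scatter), and that step is modest. No measurement shown gives a reason for this result. Open, as far as these compounds go, is how a shorter chain ending in the same amine would compare. From the compounds shown here alone, a chain ending in a morpholine or a carboxylic acid also remains open.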